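Replacing the aryl group on the amine nitrogen with cyclohexyl

The source may hold more compounds than are shown below. What is called first, only, known or untested is meant among the compounds shown, and "the series" means these compounds.

Measured compounds:
compound 1 `Cc1ccc(S(=O)(=O)/N=C(/CCNC2=CC(=O)c3ccccc3C2=O)Nc2ccc(Cl)cc2)cc1` — 13400 nM
compound 2 `Cc1ccc(S(=O)(=O)/N=C(/CCNC2=CC(=O)c3ccccc3C2=O)Nc2cccc(C)c2)cc1` — 9060 nM
compound 3 `Cc1ccc(S(=O)(=O)/N=C(/CCNC2=CC(=O)c3ccccc3C2=O)NCc2ccccc2)cc1` — 3980 nM

All three share one core and differ only in the group carried by an amine nitrogen. In a functional assay on HeLa cells (Homo sapiens) for cytotoxicity, read by MTT assay, with a stated time of 48 h (a higher number here means a weaker inhibitor, a lower number a stronger inhibitor), compound 1 gives 13400 nM, the highest number of the three; compound 2 sits within the scatter of it, while compound 3 is clearly lower. The recorded steps are a 1.5-fold lower number from compound 1 to compound 2 (0.17 log units; within the scatter), a 3.4-fold lower number from compound 1 to compound 3 (0.53 log units; beyond the scatter) and a 2.3-fold lower number from compound 2 to compound 3 (0.36 log units; beyond the scatter).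

Compound 4 `Cc1ccc(S(=O)(=O)/N=C(/CCNC2=CC(=O)c3ccccc3C2=O)NC2CCCCC2)cc1` has not yet been measured. It differs from compound 1 in one place: cyclohexyl in place of 4-chlorophenyl on an amine nitrogen. Going by the values given here, no measured step replaces an aromatic ring with a saturated one, so the closest guide is the step to compound 3, where a benzyl group attached through a non-aromatic carbon gave a modest lowering, a 3.4-fold lower number from compound 1 to compound 3 (0.53 log units; beyond the scatter); the step to compound 2, a 1.5-fold lower number from compound 1 to compound 2 (0.17 log units; within the scatter), shows that a change within the aromatic ring itself hardly moved the number. A modest lowering beyond the scatter is therefore expected, a 1.9-fold lower number from compound 1 to compound 4 (0.28 log units; within the scatter). Compound 4 is expected to give about 7000 nM in this assay, within the range 3000 nM to 18000 nM.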

Compound 4, half-maximal inhibitory concentration: 9770 nM
The estimate for compound 4 lay 1.4-fold (0.14 log units) below the measured number, within the range that was stated.
By their numbers in this assay, from the lowest: compound 3; then compounds 2, 4 and 1 (each within the scatter of the next).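

In this assay, putting the saturated cyclohexyl in place of the aromatic 4-chlorophenyl on this amine nitrogen gave a 1.4-fold lower number from compound 1 to compound 4 (0.14 log units; within the scatter), and the step from the other aromatic group gave a 1.1-fold higher number from compound 2 to compound 4 (0.03 log units; within the scatter), so in these compounds a six-membered ring of carbon only reads alike whether it is aromatic or non-aromatic. Compound 3 stays apart, with a 2.5-fold higher number from compound 3 to compound 4 (0.39 log units; beyond the scatter), which shows that a non-aromatic carbon on the nitrogen does not by itself go with the lower number, since cyclohexyl has one as well as benzyl. Nothing available accounts for why benzyl alone stands apart among these four groups.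

As far as these compounds go, whether the lower number belongs to benzyl in particular remains open, and a cyclohexylmethyl group or the longer 2-phenylethyl chain on the same nitrogen would separate the role of the carbon link from that of the aromatic ring. Also open, from the compounds shown here alone, is how a ring carrying an amine or a carboxylic acid would read at this position.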